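A few compounds are considered here, and "the series" means these few. Any claim that something is new, unique, unknown or untested is made for them only; others in the source may bear on it.

In a functional assay on SK-BR-3 cells (Homo sapiens) for inhibition, read by resazurin assay, with a stated time of 72 h (a lower number here means a stronger inhibitor, a higher number a weaker inhibitor), compound 1 `C=CC(=O)Nc1cc(N)nc(Sc2c(OC)nc(N3CCCCC3)nc2OC)n1` gives 9000 nM. Compound 2 `C=CC(=O)Nc1cc(N)nc(Sc2c(OC)nc(N3CCN(C)CC3)nc2OC)n1` gives 800 nM in this assay; it differs from compound 1 by 4-methylpiperazin-1-yl in place of piperidin-1-yl on an aromatic carbon, and this change made an 11-fold lower number from compound 1 to compound 2 (1.05 log units; beyond the scatter). Compound 3 `C=CC(=O)Nc1cc(N)nc(Sc2c(OCC)nc(N3CCCCC3)nc2OCC)n1` gives 7000 nM in this assay; the difference between the cores of compound 1 and compound 3 is not broken down here. Compound 4 `C=CC(=O)Nc1cc(N)nc(Sc2c(OCC)nc(N3CCN(C)CC3)nc2OCC)n1` has not yet been measured. Going by the values given here, it differs from compound 3 by 4-methylpiperazin-1-yl in place of piperidin-1-yl on an aromatic carbon, the same kind of change as the one from compound 1 to compound 2, though here the place is meta to two ethoxy groups rather than meta to two methoxy groups. Since the earlier instance gave an 11-fold lower number from compound 1 to compound 2 (1.05 log units; beyond the scatter), a comparable step is expected, a 10-fold lower number from compound 3 to compound 4 (1.00 log units; beyond the scatter). Compound 4 is accordingly estimated at 700 nM, with a likely range from 250 nM to 2000 nM.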

Compound 4, half-maximal inhibitory concentration: 1100 nM
Compound 4: middle estimate off by 1.6-fold (0.20 log units), on the low side; measured number inside the range.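

In this assay, the same swap of piperidin-1-yl for 4-methylpiperazin-1-yl on the ethoxy-bearing core gave a 6.4-fold lower number from compound 3 to compound 4 (0.80 log units; beyond the scatter). The change therefore carried over in the same direction, and the two steps cannot be told apart in size: the same change on two cores in this assay, an 11-fold lower number (1.05 log units; beyond the scatter) from compound 1 to compound 2 and a 6.4-fold lower number (0.80 log units; beyond the scatter) from compound 3 to compound 4, 1.8-fold (0.25 log units) apart, within the scatter of two such steps. This shows transfer only from the core of compound 1 to the core of compound 3, whose ethoxy groups replace methoxy groups, and it neither shows that the step would hold on other cores nor explains why it occurs.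

The compounds shown leave open whether a morpholin-4-yl group or a piperazine without the methyl group would behave similarly in that place. They also leave open whether the step would persist with a longer chain, such as propoxy, in place of the ethoxy groups.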